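The source may hold more compounds than are shown below. What is called first, only, known or untested is meant among the compounds shown, and "the series" means these compounds.

Compound 3 `NCC(N)CCCCNC(=O)CCn1cccc(O)c1=O` gives 81.2% in a physicochemical assay, read by spectrophotometry, with a stated time of 10 min, tested at 0.5 mM, in the presence of a further agent that is not named here; a lower number here means a weaker effect, a higher number a stronger effect of the compound at the concentration tested. Compound 1 `NCC(N)CC(=O)N1CCN(C(=O)CCn2cccc(O)c2=O)CC1` gives 68.5% in this assay, a number that lies beyond the usual scatter below that of compound 3. Compound 2 `NCC(N)CCCNC(=O)CCn1cccc(O)c1=O` gives 73.2% in this assay; the step of a number 8 percentage points higher from compound 2 to compound 3 (within the scatter) lies within the scatter, so compounds 2 and 3 cannot be told apart on this measurement. Compound 4 `NCC(N)CCCCNC(=O)CCn1cccc(OCc2ccccc2)c1=O` has not yet been measured. It differs from compound 3 in one place: benzyl in place of hydrogen on an oxygen on an aromatic ring. Among the compounds with values here, none of the measured steps bears on this change: in compounds 1, 2 and 3 alike the oxygen on the aromatic ring carries hydrogen, and the only measured step, a number 8 percentage points higher from compound 2 to compound 3 (within the scatter), concerns the saturated chain and lay within the scatter. The expectation therefore rests on the structural change alone and carries wide uncertainty. For compound 4 the expected step is a number 66.2 percentage points lower from compound 3 to compound 4 (beyond the scatter) in this assay, downward and well beyond the scatter. The estimate for compound 4 is 15%, with a range from 0% to 45%.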

Compound 4, a percentage reported as activity, at one concentration (the size of the read-out at that concentration, not a potency): 51.4%
Compound 4: the middle estimate sits 36.4 percentage points below what was measured, outside the stated range (above it).
By their numbers in this assay, from the lowest: compound 4; then compounds 1, 2 and 3 (each within the scatter of the next, the first and the last beyond it).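

Hydroxy to benzyloxy is the first change at this oxygen on an aromatic ring, and in this assay it brings a number 29.8 percentage points lower from compound 3 to compound 4 (beyond the scatter) and so, unlike the earlier step along the saturated chain, goes beyond the scatter. The read-out does not vanish, however: compound 4 still gives 51.4%, so a hydrogen on this oxygen is not required for an effect at the concentration tested, although its replacement by benzyl clearly lowers the number. No measurement at hand explains this drop.

With benzyl as the only replacement shown, the loss of the hydrogen cannot be separated from the arrival of the aromatic ring, and a methyl group on the same oxygen would help to tell the two apart. From the compounds shown here alone, whether benzyl lowers the number similarly on the shorter chain of compound 2 also remains open.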